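Pyrrolidinyl replacement on the shared core and its binding consequence

A few compounds are considered here, and "the series" means these few. Any claim that something is new, unique, unknown or untested is made for them only; others in the source may bear on it.

Measured compounds:
compound 1 `CN(c1ccc2cc(NC(=O)CCc3ccc(C(F)(F)F)cc3)ccc2n1)C1CCCC1` — 2 nM
compound 2 `O=C(CCc1ccc(C(F)(F)F)cc1)Nc1ccc2nc(N3CCC(c4ccccc4)C3)ccc2c1` — 25 nM
compound 3 `O=C(CCCCCCCCCCCCc1ccc(C(F)(F)F)cc1)Nc1ccc2nc([N+]34CCC(CC3)CC4)ccc2c1` — 5 nM

In an assay on isolated protein for displacement of a labelled ligand from melanin-concentrating hormone receptor 1 (Homo sapiens) (on this read-out higher numbers stand for weaker inhibition and lower numbers for stronger inhibition), compound 1 gives the lowest number of the three; compound 3 is nearest to it and compound 2 furthest, with a 13-fold higher number from compound 1 to compound 2 (1.10 log units; beyond the scatter). Compound 4 `CNC(=O)NC1CCN(c2ccc3cc(NC(=O)CCc4ccc(C(F)(F)F)cc4)ccc3n2)C1` has not yet been measured. It differs from compound 1 by 3-((methylcarbamoyl)amino)pyrrolidin-1-yl in place of cyclopentyl(methyl)amino on an aromatic carbon. Among the measured compounds shown here, the only step that bears on this change is the one to compound 2, where a pyrrolidin-1-yl group likewise replaced the cyclopentyl(methyl)amino group, and it was large. A loss of similar order is therefore expected for compound 4, as a 10-fold higher number from compound 1 to compound 4 (1.00 log units; beyond the scatter). Compound 4 is estimated at 20 nM, with a range from 5 nM to 80 nM.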

Compound 4, half-maximal inhibitory concentration: 6 nM
For compound 4 the middle estimate is 3.3-fold (0.52 log units) above the measured one; measured number inside the range.
By their numbers in this assay, from the lowest: compound 1; then compounds 3 and 4 (each within the scatter of the next); then compound 2.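

In this assay, a pyrrolidine ring on the aromatic carbon next to the ring nitrogen does not have to bring a large step: 3-((methylcarbamoyl)amino)pyrrolidin-1-yl in place of cyclopentyl(methyl)amino gives a 3.0-fold higher number from compound 1 to compound 4 (0.48 log units; beyond the scatter), a modest change. The group on the saturated ring carbon also matters, since (methylcarbamoyl)amino in place of phenyl gives a 4.2-fold lower number from compound 2 to compound 4 (0.62 log units; beyond the scatter). No measurement here explains either step.

The compounds shown leave open how the unsubstituted pyrrolidin-1-yl group would compare, and how an amine or a carboxylic acid would fare on that saturated ring carbon.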